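Bromine Added to the Naphthyl Ring: Cytotoxicity Outlook

A few compounds are considered here, and "the series" means these few. Any claim that something is new, unique, unknown or untested is made for them only; others in the source may bear on it.

In an ADME assay on MT4 cells (Homo sapiens) for cytotoxicity, read by MTT assay, with a stated time of 4 days (a lower number here means that less compound is tolerated, a higher number that more compound is tolerated), compound 3 `CNc1nc(Nc2ccc(C#N)cc2)nc(Oc2ccc3cc(Br)ccc3c2)n1` gives 194000 nM, the top of the two numbers shown. Its nearest neighbour is compound 1 `CCCNc1nc(Nc2ccc(C#N)cc2)nc(Oc2ccc3cc(Br)ccc3c2Br)n1`, which gives 134000 nM, a gap within the scatter. Compound 2 `CC(C)Nc1nc(Nc2ccc(C#N)cc2)nc(Oc2ccc3cc(Br)ccc3c2Br)n1` reaches only a limit in this assay, >= 209000 nM, as the limit of >= 209000 nM in this assay, at which 1 of the 3 values shown sits, records. Among the measured compounds shown here, the single measured step, an at least 1.5-fold higher number from compound 1 to compound 2 (0.19 log units; that floor lies within the scatter), concerns the group on the ring nitrogen rather than the change now considered, and it stays within the scatter. Compound 4 `CNc1nc(Nc2ccc(C#N)cc2)nc(Oc2ccc3cc(Br)ccc3c2Br)n1` differs from compound 3 by bromo in place of hydrogen on an aromatic carbon. For the measured compounds named here, no measured step covers this change, so no shift beyond the scatter is expected and the estimated step of a 1.2-fold lower number from compound 3 to compound 4 (0.08 log units; within the scatter) is small. Compound 4 is therefore expected to give about 160000 nM, between 80000 nM and 300000 nM.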

Compound 4, half-maximal cytotoxic concentration: 92800 nM
The estimate for compound 4 lay 1.7-fold (0.24 log units) above the measured number, and the stated range covers the measured number.
By their numbers in this assay, from the lowest: compounds 4, 1 and 3 (each within the scatter of the next, the first and the last beyond it). At a limit, above all of these: compound 2.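

In this assay, among the compounds shown here, bromo in place of hydrogen on an aromatic carbon, ortho to a fused ring and ortho to a large group, gives a 2.1-fold lower number from compound 3 to compound 4 (0.32 log units; beyond the scatter), the first measured step at this position and one beyond the scatter. With this bromo present, changes to the group on the nitrogen give a 1.4-fold lower number from compound 1 to compound 4 (0.16 log units; within the scatter), which stays within the scatter, and an at least 2.2-fold lower number from compound 2 to compound 4 (0.35 log units; beyond the scatter), which is only a floor. Compound 2 stands at a limit of the assay: the limit of >= 209000 nM in this assay, at which 1 of the 4 values shown sits.

Going by these compounds, whether chloro or methyl at this position would give a similar step stays open. So does whether this bromo gives the same step with propyl or isopropyl on the nitrogen.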